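The source may hold more compounds than are shown below. What is called first, only, known or untested is meant among the compounds shown, and "the series" means these compounds.

Compound 2 `C#CCSc1nc(Nc2cccc(OC)c2)c2ccncc2n1` gives 2070 nM in a functional assay on MGC-803 cells (Homo sapiens) for inhibition, read by MTT assay, with a stated time of 72 h (on this read-out lower numbers stand for stronger inhibition and higher numbers for weaker inhibition), the lowest of the three numbers recorded. Compound 1 `C#CCSc1nc(Nc2ccccc2)c2ccncc2n1` gives 16200 nM, and compound 3 `C#CCSc1nc(Nc2cccc(O)c2)c2ccncc2n1` gives 15700 nM; the steps of a 7.8-fold lower number from compound 1 to compound 2 (0.89 log units; beyond the scatter) and a 7.6-fold higher number from compound 2 to compound 3 (0.88 log units; beyond the scatter) both lie beyond the scatter, while a 1.0-fold lower number from compound 1 to compound 3 (0.01 log units; within the scatter) lies within it. Compound 4 `CCCSc1nc(Nc2cccc(OC)c2)c2ccncc2n1` differs from compound 2 by ethyl in place of ethynyl on a saturated chain carbon bound to a sulfur. Among the measured compounds shown here, all three measured steps concern the group on the aromatic ring, and not one of them touches the chain on the sulfur, so no measured step bears directly on this change. With nothing to point in either direction, the step is expected to stay within the scatter. For compound 4 the expected step is a 1.4-fold higher number from compound 2 to compound 4 (0.16 log units; within the scatter). Compound 4 is thus estimated at 3000 nM, with a range from 1000 nM to 9000 nM.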

Compound 4, half-maximal inhibitory concentration: 1950 nM
Beside the measured number, compound 4's estimate is 1.5-fold (0.19 log units) above it; low and high end bracket the measured number.
By their numbers in this assay, from the lowest: compounds 4 and 2 (each within the scatter of the next); then compounds 3 and 1 (each within the scatter of the next).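

Among the compounds shown here, until now, every measured step concerned the group on the aromatic ring, so this is the first reading of the chain on the sulfur. In this assay, propyl in place of propargyl gives a 1.1-fold lower number from compound 2 to compound 4 (0.03 log units; within the scatter), so for this pair the triple bond can be lost with no step beyond the scatter. No measured evidence is available to explain this result. Open, from the compounds shown here alone, is how a longer chain, or an amine in place of the propyl, would read, and whether the same swap would read alike with the hydroxy group of compound 3.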